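From Phenyl to Pyridin-2-yl: Expected Cytotoxicity of Compound 3

The source may report more compounds than this note shows. Statements on the series, on what has been measured and on what is new or still open speak of the compounds shown alone.

Compound 1 `Cc1ncc([N+](=O)[O-])n1CCSc1nnc(-c2ccccc2)o1` gives 17500 nM in a functional assay on HepG2 cells (Homo sapiens) for cytotoxicity, read by MTT assay, with a stated time of 48 h (on this read-out lower numbers stand for stronger inhibition and higher numbers for weaker inhibition), the highest of the two numbers measured; its nearest neighbour, compound 2 `Cc1ncc([N+](=O)[O-])n1CCSc1nnc(-c2ccccc2Cl)o1`, gives 15600 nM, and the step of a 1.1-fold lower number from compound 1 to compound 2 (0.05 log units; within the scatter) lies within the scatter. Compound 3 `Cc1ncc([N+](=O)[O-])n1CCSc1nnc(-c2ccccn2)o1` differs from compound 1 as follows: pyridin-2-yl in place of phenyl on an aromatic carbon. Among the compounds with values here, the only measured step, chloro in place of hydrogen, is a different kind of change and stayed within the scatter, so no step beyond the scatter is expected in this assay here either. Compound 3 is therefore estimated at 16000 nM, within a range of 7000 nM to 36000 nM, which means an expected step of a 1.1-fold lower number from compound 1 to compound 3 (0.04 log units; within the scatter).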

Compound 3, half-maximal inhibitory concentration: 20200 nM
For compound 3 the middle estimate is 1.3-fold (0.10 log units) below the measured one; the measured number falls inside the stated range.
By their numbers in this assay, from the lowest: compounds 2, 1 and 3 (each within the scatter of the next).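

At this position on the five-membered aromatic ring, replacing phenyl with pyridin-2-yl adds a ring nitrogen and a hydrogen-bond acceptor, yet in this assay the result is a 1.2-fold higher number from compound 1 to compound 3 (0.06 log units; within the scatter). Against the 2-chlorophenyl group the result is the same in kind, a 1.3-fold higher number from compound 2 to compound 3 (0.11 log units; within the scatter), so all three aromatic groups shown lie within the scatter of one another. Nothing available accounts for this result. As far as these compounds go, whether an amine or a carboxylic acid on the pyridine ring would give a step beyond the scatter remains open. So does the effect of a longer chain in place of the aromatic group.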